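The source may report more compounds than this note shows. Statements on the series, on what has been measured and on what is new or still open speak of the compounds shown alone.

In an assay on HL-60 cells for agonist activity at vitamin D3 receptor (Homo sapiens), read by microscopy, with a stated time of 96 h (on this read-out higher numbers stand for an effect only at larger amounts of compound and lower numbers for an effect already at smaller amounts), compound 2 `CCn1c(C(=O)NCCCN(C)C)ccc1C(CC)(CC)c1ccc(OCC(O)C(C)(C)C)c(C)c1` gives 37 nM, the lowest number among the three measured compounds; compound 1 `CCn1c(C(=O)NCCCN(C)C)ccc1C(CC)(CC)c1ccc(OCC(=O)C(C)(C)C)c(C)c1` gives 96 nM and compound 3 `CCn1c(C(=O)OC(C)CCO)ccc1C(CC)(CC)c1ccc(OCC(=O)C(C)(C)C)c(C)c1` gives 380 nM. Compound 4 `CCn1c(C(=O)OCc2ccccn2)ccc1C(CC)(CC)c1ccc(OCC(O)C(C)(C)C)c(C)c1` has not yet been measured. It differs from compound 2 in one place: (pyridin-2-yl)methoxy in place of (3-(dimethylamino)propyl)amino on a carbonyl carbon. Among the compounds with values here, one measured step bears on this change, since it too sits on the carbonyl carbon and removes the (3-(dimethylamino)propyl)amino group: a 4.0-fold higher number from compound 1 to compound 3 (0.60 log units; beyond the scatter). A step of comparable size in the same direction is therefore expected, a 3.5-fold higher number from compound 2 to compound 4 (0.55 log units; beyond the scatter). On that basis compound 4 is estimated to give about 130 nM in this assay, with a range from 50 nM to 400 nM.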

Compound 4, half-maximal effective concentration: > 50000 nM
Compound 4: no number, only a limit; the forecaster's own chance of this, stated with the estimate: 5%; middle value at least 380-fold (2.58 log units) from the limit.
By their numbers in this assay, from the lowest: compound 2; then compound 1; then compound 3. At a limit, above all of these: compound 4.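

Compound 4 gives no number in this assay, only a limit: the limit of > 50000 nM in this assay, at which 1 of the 4 values shown sits. On the carbonyl carbon, the exchange brings an at least 1300-fold higher number from compound 2 to compound 4 (3.13 log units; beyond the scatter), whereas the earlier loss of the same (3-(dimethylamino)propyl)amino group brought a 4.0-fold higher number from compound 1 to compound 3 (0.60 log units; beyond the scatter). Losing that group therefore does not have one fixed cost at this place; the size of the step differs between these two pairs.

Going by these compounds, it remains open whether (pyridin-2-yl)methoxy alone sets this step or whether the 1-hydroxy-2,2-dimethylpropyl group shares in it. A (pyridin-2-yl)methylamino group on the same carbonyl carbon would separate the pyridine ring from the ester oxygen.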